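The source may report more compounds than this note shows. Statements on the series, on what has been measured and on what is new or still open speak of the compounds shown alone.

Working notes on the series.

Of the compounds shown here, three have been measured in a functional assay on THP-1 cells (Homo sapiens) for inhibition, read by ELISA, with stated times of 30 min and 24 h, tested at 10 uM; on this read-out higher numbers stand for a stronger effect at the one concentration tested and lower numbers for a weaker effect. Compound 1 `COc1cc(O)c(C(=O)c2ccccc2Br)c(OC)c1` gives 72% and stands lowest of the three numbers. Compound 2 `COc1cc(O)c(C(=O)c2cccc(Cl)c2)c(OC)c1` gives 78%, a number higher than that of compound 1 but within the scatter. Compound 3 `COc1cc(OC)c(C(=O)c2cccc(F)c2)c(O)c1CN1CCCCC1` gives 87%, a number above that of compound 1 and beyond the scatter; the two values show that compound 3 sits clearly higher.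

The next compound, compound 4 `COc1cc(OC)c(C(=O)c2ccccc2Br)c(O)c1CN1CCCC1`, has not been measured in this assay. Relative to compound 1 the change is (pyrrolidin-1-yl)methyl in place of hydrogen on an aromatic carbon. For the measured compounds named here, no step between two measured compounds is available for this exact change, so the size can only be guessed. The step from compound 1 to compound 4 is expected to be upward and of about the size of the scatter, a number 10 percentage points higher from compound 1 to compound 4 (within the scatter). Compound 4 is therefore expected to give 82% in this assay, with a range from 70% to 92%.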

Compound 4, a percentage reported as activity, at one concentration (the size of the read-out at that concentration, not a potency): 100%
Estimate against measurement, compound 4: 18 percentage points below, outside the stated range (above it).
By their numbers in this assay, from the lowest: compounds 1, 2 and 3 (each within the scatter of the next, the first and the last beyond it); then compound 4.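

In this assay, for the compounds shown here, the change of hydrogen to (pyrrolidin-1-yl)methyl on this aromatic carbon, ortho to a hydroxy group and para to a methoxy group, gives a number 28 percentage points higher from compound 1 to compound 4 (beyond the scatter) and is the first step that can be read across a single place. The earlier compounds shown here offered no such pair, so they could not show that this carbon accepts a substituent of this kind and that the number moves beyond the scatter when it does. No measurement at hand says why the number rises.

The compounds shown leave open whether the pyrrolidine ring itself matters, since a dimethylaminomethyl or morpholin-4-ylmethyl group on the same carbon does not appear among them. They also leave open whether a plain methyl group there would give a similar step.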